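The source may report more compounds than this note shows. Statements on the series, on what has been measured and on what is new or still open speak of the compounds shown alone.

Measured so far in an ADME assay on HepG2 2.2.15 cells (Homo sapiens) for cytotoxicity, read by CCK-8 assay, with a stated time of 8 days (a higher number here means that more compound is tolerated, a lower number that less compound is tolerated), are two compounds:
- compound 1 `CCOc1ccc(-c2cc(NC(=O)c3ccc(OC)cc3O)c[nH]c2=O)cc1` with 69600 nM
- compound 2 `CCOc1ccc(-c2cc(NC(=O)c3cc(OC)ccc3O)c[nH]c2=O)cc1` with 57700 nM

Compound 1 has a single measured neighbour, compound 2, and the two sit within the scatter of each other, so neither stands apart from the other.

Compound 3 `COc1ccc(C(=O)Nc2c[nH]c(=O)c(-c3ccc(OC)c(F)c3)c2)c(O)c1` keeps the 2-hydroxy-4-methoxyphenyl on the carbonyl carbon of compound 1. It carries 3-fluoro-4-methoxyphenyl in place of 4-ethoxyphenyl, on an aromatic carbon of a six-membered aromatic ring with 1 nitrogen (3-fluoro-4-methoxyphenyl in place of 4-ethoxyphenyl on an aromatic carbon).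

Among the compounds with values here, no measured step touches that place. Within the data shown here, the only measured step lies on the carbonyl side of the molecule and is small (a 1.2-fold lower number from compound 1 to compound 2 (0.08 log units; within the scatter)), so it bears on this change only loosely. It gives no sign of a large shift, but it cannot rule one out.

In this assay no step beyond the scatter is therefore expected, and the estimated change is small (a 1.2-fold lower number from compound 1 to compound 3 (0.06 log units; within the scatter)). Compound 3 is expected at 60000 nM (estimated range 25000 nM to 120000 nM).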

Compound 3, half-maximal cytotoxic concentration: 50500 nM
Compound 3: middle estimate off by 1.2-fold (0.07 log units), on the high side; the measured number falls inside the stated range.
By their numbers in this assay, from the lowest: compounds 3, 2 and 1 (each within the scatter of the next).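

Within the data shown here, this is the first measured change to the aryl group on the ring that holds the nitrogen; the earlier step touched only the carbonyl side. In this assay, 3-fluoro-4-methoxyphenyl in place of 4-ethoxyphenyl gives a 1.4-fold lower number from compound 1 to compound 3 (0.14 log units; within the scatter) and so stays within the usual scatter, which means that this position accepts this swap of two groups with the same heavy-atom count without a clear shift in tolerated concentration. No supporting measurement bears on this result.

As far as these compounds go, the step combines two edits, the added fluorine and methoxy in place of ethoxy, so the contribution of each one alone remains open. Also open, from the compounds shown here alone, is whether a more different group at this position, such as an amine or a carboxylic acid on the aryl ring or a longer chain in place of the ethoxy, would move the number beyond the scatter.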